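The source may hold more compounds than are shown below. What is called first, only, known or untested is meant among the compounds shown, and "the series" means these compounds.

Measured so far:
Compound 1 `COc1ccc2nc(C)cc(NCc3cccc(F)c3)c2c1` gives 14700 nM
Compound 2 `COc1ccc2nc(C)cc(NCc3cccc(OC(F)F)c3)c2c1` gives 14300 nM
Compound 3 `COc1ccc2nc(C)cc(NCc3cccc(C#N)c3)c2c1` gives 17400 nM

All three numbers come from a functional assay on MCF-10A cells (Homo sapiens) for antiproliferative activity, with a stated time of 48 h; on this read-out higher numbers stand for an effect only at larger amounts of compound and lower numbers for an effect already at smaller amounts. Compound 3 cannot be separated from the other two: the comparisons are a 1.2-fold higher number from compound 1 to compound 3 (0.07 log units; within the scatter) and a 1.2-fold higher number from compound 2 to compound 3 (0.09 log units; within the scatter).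

The next compound is compound 4 `COc1ccc2nc(C)cc(NCc3cccc(CO)c3)c2c1`, which carries hydroxymethyl in place of cyano on an aromatic carbon. The place is the one already varied among the measured compounds, an aromatic carbon of a six-membered aromatic ring of carbon only, meta to a large group.

Among the measured compounds shown here, three measured steps bear on this change: a 1.0-fold lower number from compound 1 to compound 2 (0.01 log units; within the scatter), a 1.2-fold higher number from compound 1 to compound 3 (0.07 log units; within the scatter) and a 1.2-fold higher number from compound 2 to compound 3 (0.09 log units; within the scatter). Each exchanges one group at that place, and none leaves the scatter. These steps give no sign of a large effect in this assay from exchanging a group there. However, no measured compound carries hydroxymethyl, so the change itself is untested, and the range has to stay wider than the spread of the three values.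

No step beyond the scatter is expected, in either direction, and the expected step is a 1.1-fold lower number from compound 3 to compound 4 (0.04 log units; within the scatter).

For compound 4 the estimated value is 16000 nM, with an expected range from 8000 nM to 32000 nM.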

Compound 4, half-maximal effective concentration: 24700 nM
For compound 4 the middle estimate is 1.5-fold (0.19 log units) below the measured one; the measured number falls inside the stated range.
By their numbers in this assay, from the lowest: compounds 2, 1, 3 and 4 (each within the scatter of the next).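

Hydroxymethyl is the first group at this place for which a hydrogen-bond donor is counted, where cyano has none, and in this assay the exchange still stays within the scatter, with a 1.4-fold higher number from compound 3 to compound 4 (0.15 log units; within the scatter). Among the compounds shown here, the same holds against the two other groups, with a 1.7-fold higher number from compound 2 to compound 4 (0.24 log units; within the scatter) and a 1.7-fold higher number from compound 1 to compound 4 (0.23 log units; within the scatter), so the four compounds cannot be put in any order, and across these four groups, the exchange on this aromatic carbon gives no step that can be read as a real change. No measurement at hand explains why these exchanges stay so small, and the data offer no cause for it.

Still open, going by these compounds, is whether a group of another kind at this place, such as an amine, a carboxylic acid or a longer chain, would produce a step beyond the scatter in this assay. Also open, on these data alone, is whether exchanging the methoxy or the methyl group on the shared core, or the amine link to the substituted ring, would move the number when this place stays fixed.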